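The compounds below may be only part of what the source reports. "The series", "measured", "known", "first", "only" and "open" are said of these compounds alone.

Measured compounds: compound 1 `COCc1nc(Br)c2cnnc(O)n12`, > 48000 nM; compound 2 `C=CCn1nc(Br)c2c(Br)nc(CCC)n2c1=O`, > 48000 nM.

In a functional assay for inhibition, with Homo sapiens as the target (on this read-out lower numbers stand for stronger inhibition and higher numbers for weaker inhibition), compound 1 gives > 48000 nM, a limit of the assay and not a number. Compound 2 gives > 48000 nM in this assay, likewise a limit. Going by the values given here, both results sit at the same bound, (the limit of > 48000 nM in this assay, at which 2 of the 2 values shown sit), so compound 1 stands at that bound and nowhere else can be placed; no step between measured compounds can be read. Compound 3 `CCCc1nc(Br)c2cnnc(O)n12` differs from compound 1 by ethyl in place of methoxy on a saturated chain carbon bound to an aromatic carbon. With both known values at the limit, the step meant here, a step that the limit leaves unreadable from compound 1 to compound 3, is expected to lie within the scatter in this assay. Compound 3 is expected at 70000 nM, within 20000 nM to 250000 nM, most likely again reported only as a limit.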

Compound 3, half-maximal inhibitory concentration: > 48000 nM
Compound 3 was reported as a limit; the forecaster's own chance of this, stated with the estimate: 85%; the middle value does not contradict the limit.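

No step can be read from compound 1 to compound 3, as both are reported only as limits: the limit of > 48000 nM in this assay, at which 3 of the 3 values shown sit. The compounds shown leave open which change to the shared core, if any, would give a value inside the measurable range.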